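Side-chain swaps on the shared diketopiperazine-free core series

The source may hold more compounds than are shown below. What is called first, only, known or untested is meant among the compounds shown, and "the series" means these compounds.

In a functional assay (on this read-out lower numbers stand for stronger inhibition and higher numbers for weaker inhibition), compound 1 `CC(C)C[C@@H]1NC(=O)[C@H](Cc2cnc[nH]2)NC1=O` gives 850000 nM, the highest number of the three measured. Compound 2 `CC(C)C[C@@H]1NC(=O)[C@H](CCC(=O)O)NC1=O` gives 80000 nM and compound 3 `CC(C)C[C@@H]1NC(=O)[C@H](CCCCN)NC1=O` gives 160000 nM in this assay. The unmeasured compound 4 `CC(C)C[C@@H]1NC(=O)[C@H](CC(=O)O)NC1=O` carries the change (carboxy in place of 1H-imidazol-5-yl on a saturated chain carbon bound to a saturated ring carbon). The step that bears on it most directly is an 11-fold lower number from compound 1 to compound 2 (1.03 log units; beyond the scatter), which places the same carboxy one chain atom further out; the step of a 5.3-fold lower number from compound 1 to compound 3 (0.73 log units; beyond the scatter) also points the same way. A step of comparable size and the same direction in this assay is therefore expected for compound 4, shortening the carboxymethyl of compound 2 by one carbon and allowing for some loss. Compound 4 is estimated at 120000 nM, between 40000 nM and 400000 nM, the expected step being a 7.1-fold lower number from compound 1 to compound 4 (0.85 log units; beyond the scatter).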

Compound 4, half-maximal inhibitory concentration: 4000 nM
The estimate for compound 4 lay 30-fold (1.48 log units) above the measured number, and the stated range ends above it.
By their numbers in this assay, from the lowest: compound 4; then compounds 2 and 3 (each within the scatter of the next); then compound 1.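

Side-chain length counts at this position: compound 2 and compound 4 both end in carboxy, yet the shorter chain gives a 20-fold lower number from compound 2 to compound 4 (1.30 log units; beyond the scatter) in this assay. Compound 4 also stands apart from the side chains carrying other groups, with a 40-fold lower number from compound 3 to compound 4 (1.60 log units; beyond the scatter) and a 210-fold lower number from compound 1 to compound 4 (2.33 log units; beyond the scatter), a wider gap than any among compound 1, compound 2 and compound 3. Nothing available bears on the reason for this result.

Going by these compounds, whether the carboxy group itself is needed stays open. An aminomethyl or a carboxamide in its place would separate the group from the chain length.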